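Opening an Amide Ring on the Pyridine Side Chain

The source may hold more compounds than are shown below. What is called first, only, known or untested is meant among the compounds shown, and "the series" means these compounds.

Measured so far:
- compound 1, `CCC(=O)NCc1cncc(N2C(=O)c3ccc(Cl)cc3C2(C)C)c1`: 282 nM
- compound 2, `Cc1cccnc1C(=O)NCc1cncc(N2C(=O)c3ccc(Cl)cc3C2(C)C)c1`: 9 nM
- compound 3, `CC(=O)N1CC[C@@H](Oc2cncc(N3C(=O)c4ccc(Cl)cc4C3(C)C)c2)C1`: 11 nM

Compound 3 stands among three numbers from an assay on cells for inhibition of cytochrome P450 11B2, mitochondrial (Homo sapiens), read by HTRF (on this read-out lower numbers stand for stronger inhibition and higher numbers for weaker inhibition), with compound 2 at a value within the scatter of its own, while compound 1 lies far above it, a 26-fold lower number from compound 1 to compound 3 (1.41 log units; beyond the scatter). The piece follows the step from compound 3 to compound 4, `CC(=O)NCc1cncc(N2C(=O)c3ccc(Cl)cc3C2(C)C)c1`, in which (a group of 5 heavy atoms (3 carbon, 1 nitrogen, 1 oxygen; no ring) in place of a group of 9 heavy atoms (6 carbon, 1 nitrogen, 2 oxygen; one five-membered non-aromatic ring with 1 hetero atom), on an aromatic carbon). Within the data shown here, two measured steps bear on it. The step of a 26-fold lower number from compound 1 to compound 3 (1.41 log units; beyond the scatter) shows that replacing the acyclic amide chain of compound 1 with the five-membered ring of compound 3 brought a large drop in the number, and the step of a 31-fold lower number from compound 1 to compound 2 (1.50 log units; beyond the scatter) shows that an aryl group on the carbonyl carbon did much the same. Compound 4 goes the other way: it gives up the ring and returns to an acyclic amide of the kind present in compound 1, shorter by one carbon. A large rise in the number is therefore expected, roughly the reverse of the step from compound 1 to compound 3. In this assay compound 4 is expected to give about 350 nM, within a range of 120 nM to 1000 nM. The expected step is a 32-fold higher number from compound 3 to compound 4 (1.50 log units; beyond the scatter).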

Compound 4, half-maximal inhibitory concentration: 59 nM
Estimate against measurement, compound 4: 5.9-fold (0.77 log units) above, outside the stated range (below it).
By their numbers in this assay, from the lowest: compounds 2 and 3 (each within the scatter of the next); then compound 4; then compound 1.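

In this assay, the position on the pyridine-bearing side chain proves sensitive to a very small edit on the carbonyl carbon: a 4.8-fold lower number from compound 1 to compound 4 (0.68 log units; beyond the scatter) is beyond the scatter and comes only from hydrogen in place of methyl on the saturated chain carbon, so an open-chain amide does not by itself bring a number as high as that of compound 1. Among these compounds, with acetamidomethyl in place, a 5.4-fold higher number from compound 3 to compound 4 (0.73 log units; beyond the scatter) and a 6.6-fold higher number from compound 2 to compound 4 (0.82 log units; beyond the scatter) are both modest, whereas the earlier steps from compound 1, a 26-fold lower number from compound 1 to compound 3 (1.41 log units; beyond the scatter) and a 31-fold lower number from compound 1 to compound 2 (1.50 log units; beyond the scatter), were large, so the size of what the ring or the 3-methylpyridin-2-yl group appears to add depends on which open-chain amide serves as the reference. Nothing available gives a reason for any of these steps.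

The change from compound 3 to compound 4 alters the ring, the linking atoms and the amide hydrogen all at once, so these shown compounds cannot divide its effect among them. They also leave open how the number responds to a hydrogen or a cyclopropyl group directly on the carbonyl carbon, or to a longer chain such as butyl there.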